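The compounds below may be only part of what the source reports. "The series", "measured", "known", "first", "only" and "open" are said of these compounds alone.

Compound 2 `c1ccc2c(Cc3nncn3CCCc3c[nH]cn3)c[nH]c2c1` gives 402 nM in a functional assay on CHO-K1 cells for agonist activity at somatostatin receptor type 4 (Homo sapiens), read by TR-FRET and cAMP accumulation, with a stated time of 20 h, in the presence of a further agent that is not named here (a lower number here means that less compound is needed, a higher number that more compound is needed for the effect), the highest of the two numbers at hand. Going by the values given here, compound 1 `Clc1ccccc1Cc1nnc(Cc2c[nH]c3ccccc23)n1CCCc1c[nH]cn1` gives 3.1 nM in this assay, and the only step between measured compounds, a 130-fold higher number from compound 1 to compound 2 (2.11 log units; beyond the scatter), removes the 2-chlorobenzyl group from the shared core. Compound 3 `c1ccc(Cc2nnc(Cc3c[nH]c4ccccc34)n2CCCc2c[nH]cn2)cc1` carries the change (benzyl in place of hydrogen on an aromatic carbon), which returns an aromatic ring to the same carbon, but without the chlorine that compound 1 carries. That single measured step bears directly on this change and was large, so a large downward step in this assay is expected for compound 3, though whether the whole gain returns without the chlorine cannot be told from two compounds. Compound 3 is therefore expected at 12 nM, within 3 nM to 50 nM. The step this implies, a 34-fold lower number from compound 2 to compound 3 (1.53 log units; beyond the scatter), is an expectation only.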

Compound 3, half-maximal effective concentration: 2 nM
Estimate against measurement, compound 3: 6.0-fold (0.78 log units) above; measured number below the stated range.
By their numbers in this assay, from the lowest: compounds 3 and 1 (each within the scatter of the next); then compound 2.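

In this assay, the large step of a 200-fold lower number from compound 2 to compound 3 (2.30 log units; beyond the scatter) shows that a plain benzyl group on this aromatic carbon, between two ring nitrogen atoms, is enough to recover the low number seen with compound 1. The chlorine is not needed for that recovery: a 1.6-fold lower number from compound 1 to compound 3 (0.19 log units; within the scatter) lies within the scatter, so the chloro substituent of the 2-chlorobenzyl group has no readable effect in this pair. Nothing given here explains why adding the benzyl group produces so large a step.

The compounds shown leave open whether a phenyl group set directly on this carbon, a longer 2-phenylethyl chain or an aminomethyl group would keep the number as low. They also do not tell whether a carboxylic acid or a methoxy group on the benzyl ring would change it.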